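Compound 3 and a Change at the Chain Carbon

This account rests on a few compounds, and the source may have more. Where it says the series, first, only, none or still open, it means among the compounds named here.

Compound 3 `Nc1cccc(-c2cn3nc(Cc4ccc(Cl)cc4)sc3n2)c1` gives 16000 nM in a functional assay on L1210 cells (Mus musculus) for inhibition, read by cell counting, with a stated time of 2 days (on this read-out higher numbers stand for weaker inhibition and lower numbers for stronger inhibition), the highest of the three numbers recorded, making it the weakest inhibitor of the set. Compound 1 `C=C(Br)C(=O)Nc1cccc(-c2cn3nc(-c4ccc(OCC)cc4)sc3n2)c1` gives 790 nM in this assay, and compound 2 `C=C(Br)C(=O)Nc1cccc(-c2cn3nc(CCc4ccccc4)sc3n2)c1` gives 2200 nM. The step of a 2.8-fold higher number from compound 1 to compound 2 (0.44 log units; beyond the scatter) is the only measured pairing, and it concerns the group on the aromatic carbon of the shared core, not the position altered here. Compound 4 `COc1cccc(Cc2nn3cc(-c4cccc(N)c4)nc3s2)c1` differs from compound 3 by 3-methoxyphenyl in place of 4-chlorophenyl on a saturated chain carbon bound to an aromatic carbon. Among the compounds with values here, no measured step tests such an exchange, so no shift beyond the scatter is expected, and compound 4 is estimated at 14000 nM with a range of 5000 nM to 40000 nM. The expected step is therefore a 1.1-fold lower number from compound 3 to compound 4 (0.06 log units; within the scatter).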

Compound 4, half-maximal inhibitory concentration: 21000 nM
For compound 4 the middle estimate is 1.5-fold (0.18 log units) below the measured one, within the range that was stated.
By their numbers in this assay, from the lowest: compound 1; then compound 2; then compounds 3 and 4 (each within the scatter of the next).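

At a saturated chain carbon bound to an aromatic carbon, 3-methoxyphenyl in place of 4-chlorophenyl gives a 1.3-fold higher number from compound 3 to compound 4 (0.12 log units; within the scatter) in this assay and so separates compound 3 and compound 4 by no more than repeat measurements would. Within the data shown here, this is the first exchange seen at this position, and here a methoxy-bearing ring can stand in for a chlorine-bearing ring without a measurable shift. No supporting measurement bears on why the two numbers agree. On these data alone, whether a carboxylic acid on this ring or a longer chain at this carbon would shift the number remains open.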